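Acetylation of the Aniline Nitrogen in an Inactive Series

This account rests on a few compounds, and the source may have more. Where it says the series, first, only, none or still open, it means among the compounds named here.

Measured so far:
compound 1, `CCC(CC)c1ccc(NC(=O)c2c(-c3c(Cl)cccc3Cl)noc2C)cc1` — > 10000 nM
compound 2, `CCN(CC)Cc1ccc(NC(=O)c2c(-c3c(Cl)cccc3Cl)noc2C)cc1` — > 10000 nM
compound 3, `CCNc1ccc(NC(=O)c2c(-c3c(Cl)cccc3Cl)noc2C)cc1` — > 10000 nM

Of the compounds shown here, three sharing one core have been tested in an assay on isolated protein for binding affinity to growth hormone secretagogue receptor type 1 (Homo sapiens); on this read-out higher numbers stand for weaker inhibition and lower numbers for stronger inhibition. Compound 1 gives > 10000 nM, which is a limit of the assay and not a number. Compound 2 likewise gives > 10000 nM, a limit. Compound 3 gives > 10000 nM, again a limit. Compound 3 therefore stands at the same limit as the other two, with no measurable difference among them.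

The step that the two limits leave unreadable from compound 1 to compound 2 cannot be read, and the same holds for a step that the two limits leave unreadable from compound 1 to compound 3 and a step that the two limits leave unreadable from compound 2 to compound 3, because all three values sit at the limit of > 10000 nM in this assay, at which 3 of the 3 values shown sit. None of them can show whether a change at this aromatic carbon moves binding at all.

Compound 4, `CCN(C(C)=O)c1ccc(NC(=O)c2c(-c3c(Cl)cccc3Cl)noc2C)cc1`, is the next compound to be measured. It differs from compound 3 by acetyl in place of hydrogen on a nitrogen on an aromatic ring. Going by the values given here, no measured step bears readably on this change; the only guidance is that every compound so far, including compound 3 with > 10000 nM, has remained at the limit. Compound 4 is therefore expected to give 20000 nM, with a range from 5000 nM to 100000 nM. The expected step that the limit leaves unreadable from compound 3 to compound 4 is one of no readable size from a limit, with a numerical value considered unlikely.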

Compound 4, half-maximal inhibitory concentration: > 10000 nM
Compound 4: no number, only a limit; the forecaster's own chance of this, stated with the estimate: 85%; the middle value does not contradict the limit.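

In this assay compound 4 gives > 10000 nM, which is a limit of the assay and not a number. Going by these compounds alone, no step linking compound 4 with compound 1, compound 2 or compound 3 can be read, because all four values stand at one limit: the limit of > 10000 nM in this assay, at which 4 of the 4 values shown sit. The compounds shown leave open whether acetyl on this nitrogen, or any other change shown, moves binding at all.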